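Bromo for chloro on a weakly active compound

A few compounds are considered here, and "the series" means these few. Any claim that something is new, unique, unknown or untested is made for them only; others in the source may bear on it.

In a functional assay on thoracic aorta (Rattus norvegicus, strain Wistar), with a stated time of 15 min (a higher number here means that more compound is needed for the effect, a lower number that less compound is needed), compound 1 `COc1ccc(Cl)cc1C(C)NC(=O)N(C)S(=O)(=O)c1ccc(Cl)cc1` gives 20000 nM and compound 2 `CCOc1ccc(Cl)cc1C(C)NC(=O)N(C)S(=O)(=O)c1ccc(Cl)cc1` gives 14600 nM, so these two values lie within the scatter of each other. Compound 3 `CCOc1ccc(Br)cc1C(C)NC(=O)N(C)S(=O)(=O)c1ccc(Cl)cc1` differs from compound 2 by bromo in place of chloro on an aromatic carbon. Among the compounds with values here, the only measured step, a 1.4-fold lower number from compound 1 to compound 2 (0.14 log units; within the scatter), is a different change, methyl in place of hydrogen, so it offers little guidance and shows no large shift. No step beyond the scatter is expected in this assay. The expected step is a 1.0-fold lower number from compound 2 to compound 3 (0.02 log units; within the scatter). Compound 3 is estimated at 14000 nM, with an expected range of 5500 nM to 35000 nM.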

Compound 3, half-maximal effective concentration: 55700 nM
Compound 3: the middle estimate sits 4.0-fold (0.60 log units) below what was measured; measured number above the stated range.
By their numbers in this assay, from the lowest: compounds 2 and 1 (each within the scatter of the next); then compound 3.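

Bromo in place of chloro on this aromatic carbon, para to an ethoxy group, gives a 3.8-fold higher number from compound 2 to compound 3 (0.58 log units; beyond the scatter) in this assay and so means that more compound is needed for the effect. Exchanging one halogen for another at this position therefore moves the number beyond the scatter, whereas the earlier change at the alkoxy group stayed within it. Nothing available explains this shift. From the compounds shown here alone, how fluoro, methyl or a nitrile at this carbon would compare remains open, as does whether bromo gives a similar step when the methoxy group of compound 1 replaces ethoxy.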